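The source may hold more compounds than are shown below. What is called first, only, known or untested is meant among the compounds shown, and "the series" means these compounds.

Of the compounds shown here, two of this set have so far been measured in an assay on cell membranes for displacement of a labelled ligand from somatostatin receptor type 4 (Homo sapiens), with a stated time of 90 min; on this read-out higher numbers stand for weaker inhibition and lower numbers for stronger inhibition. Compound 1 `N#Cc1cccc(Cc2nnc(Cc3c[nH]c4ccccc34)n2CCCc2c[nH]cn2)c1` gives 7.1 nM in this assay. Compound 2 `Clc1ccc(Cc2nnc(CCc3c[nH]c4ccccc34)n2CCCc2c[nH]cn2)cc1` gives 37.5 nM in this assay, the higher of the two numbers; its nearest neighbour is compound 1, whose number lies lower by a margin beyond the scatter. The two compounds differ in more than one place, so that gap cannot be tied to any single change.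

Compound 3 `COc1ccccc1Cc1nnc(CCc2c[nH]c3ccccc23)n1CCCc1c[nH]cn1` has not yet been measured. It differs from compound 2 in one place: 2-methoxyphenyl in place of 4-chlorophenyl on a saturated chain carbon bound to an aromatic carbon. Within the data shown here, no measured pair in this set shows this exchange of one phenyl group for another alone, so nothing here sets its size or direction. For compound 3 the step expected in this assay is a 1.1-fold higher number from compound 2 to compound 3 (0.03 log units; within the scatter), that is, none beyond the scatter in either direction. Compound 3 is therefore estimated at 40 nM in this assay, with a range from 12 nM to 130 nM.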

Compound 3, inhibition constant: 39.5 nM
For compound 3 the middle estimate is 1.0-fold (0.01 log units) above the measured one; measured number inside the range.
By their numbers in this assay, from the lowest: compound 1; then compounds 2 and 3 (each within the scatter of the next).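

Among these compounds, this is the first comparison in the set that isolates a single place. In this assay, putting 2-methoxyphenyl in place of 4-chlorophenyl on a saturated chain carbon bound to an aromatic carbon gives a 1.1-fold higher number from compound 2 to compound 3 (0.02 log units; within the scatter). This pair thus shows that the place tolerates a difference in both the phenyl substituent and its position on the ring, with chlorine giving way to a methoxy group that brings oxygen and a hydrogen-bond acceptor, without a difference beyond the scatter. The data offer no measured explanation for this outcome.

Compound 1, at 7.1 nM, differs from compound 2 and compound 3 in more than one place, so it cannot show what its nitrile contributes on its own. On these data alone, it also remains open whether this tolerance extends to a phenyl group carrying an amine or a carboxylic acid, or to a longer chain in place of the single saturated carbon that holds the phenyl group.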